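Nitro for methoxy on the 4-methoxyphenyl end

The compounds below may be only part of what the source reports. "The series", "measured", "known", "first", "only" and "open" are said of these compounds alone.

Three members of the series are measured. Compound 1 `COc1ccc(C(=O)c2cc(OC)c(OC)c(OC)c2)cc1NC(=O)/C=C/c1ccc(OC)c(OC)c1` gives 7500 nM in a functional assay on PC-3 cells (Homo sapiens) for cytotoxicity, read by MTT assay, with a stated time of 72 h; on this read-out higher numbers stand for weaker inhibition and lower numbers for stronger inhibition. Compound 2 `COc1ccc(/C=C/C(=O)Nc2cc(C(=O)c3cc(OC)c(OC)c(OC)c3)ccc2OC)cc1` gives 11100 nM in this assay, the second highest of the three numbers. Compound 3 `COc1ccc(C(=O)c2cc(OC)c(OC)c(OC)c2)cc1NC(=O)/C=C/c1ccc(N)cc1` gives 15900 nM. Compound 2 sits within the scatter of both neighbours: a 1.5-fold higher number from compound 1 to compound 2 (0.17 log units; within the scatter) and a 1.4-fold higher number from compound 2 to compound 3 (0.16 log units; within the scatter), while the larger change gives a 2.1-fold higher number from compound 1 to compound 3 (0.33 log units; beyond the scatter), a modest step.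

Compound 4 `COc1ccc(C(=O)c2cc(OC)c(OC)c(OC)c2)cc1NC(=O)/C=C/c1ccc([N+](=O)[O-])cc1` is not yet measured. Relative to compound 2 the change is nitro in place of methoxy on an aromatic carbon. Among the compounds with values here, the steps that bear on it are the two in which the same aromatic carbon is altered, hydrogen or amino in place of methoxy, and both stayed within the scatter. A step of the same kind is therefore expected here, with no direction beyond the scatter: compound 4 is expected to show a 1.1-fold higher number from compound 2 to compound 4 (0.03 log units; within the scatter). The estimate for compound 4 in this assay is 12000 nM, with a range from 6000 nM to 25000 nM.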

Compound 4, half-maximal inhibitory concentration: 10400 nM
The estimate for compound 4 lay 1.2-fold (0.06 log units) above the measured number; measured number inside the range.
By their numbers in this assay, from the lowest: compounds 1, 4, 2 and 3 (each within the scatter of the next, the first and the last beyond it).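

In this assay, nitro is now the third group on this aromatic carbon, and its replacement of methoxy stays within the scatter (a 1.1-fold lower number from compound 2 to compound 4 (0.03 log units; within the scatter)). Nitro and amino at this carbon are also not separated (a 1.5-fold lower number from compound 3 to compound 4 (0.18 log units; within the scatter)), so methoxy, amino and nitro give numbers that cannot be told apart here. The 4-aminophenyl end lies beyond the scatter from the 3,4-dimethoxyphenyl end of compound 1, whereas the 4-nitrophenyl end does not (a 1.4-fold higher number from compound 1 to compound 4 (0.14 log units; within the scatter)), although compound 3 and compound 4 remain within the scatter of each other.

No measurement at hand accounts for these results.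

As far as these compounds go, whether any group at this carbon can move the number beyond the scatter remains open, for example a carboxylic acid or a longer chain such as butoxy.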